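This account rests on a few compounds, and the source may have more. Where it says the series, first, only, none or still open, it means among the compounds named here.

Measured compounds in a functional assay on MCF7 cells (Homo sapiens) for cytotoxicity, read by MTT assay, with a stated time of 4 days; a higher number here means a weaker inhibitor, a lower number a stronger inhibitor:
Compound 1 `C=C1C[C@]23C[C@@]1(O)CC[C@H]2c1ccc(OS(=O)(=O)c2ccc(C)cc2)c(C)c1[C@@H]3Cn1cc(-c2ccc(Cl)cc2)nn1`: > 20000 nM, a limit of the assay
Compound 2 `C=C1C(=O)[C@]23C[C@@]1(O)CC[C@H]2c1ccc(OS(=O)(=O)c2ccc(C)cc2)c(C)c1[C@@H]3Cn1cc(-c2ccc(Br)cc2)nn1`: 250 nM
Compound 3 `C=C1C[C@]23C[C@@]1(O)CC[C@H]2c1ccc(OS(=O)(=O)c2ccc(C)cc2)c(C)c1[C@@H]3Cn1cc(-c2ccc(Br)cc2)nn1`: > 20000 nM, a limit of the assay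

Compound 2 is the only one of the three that returns a number in this assay. Compound 1 and compound 3 both sit at the limit of > 20000 nM in this assay, at which 2 of the 3 values shown sit, so no potency can be read for either of them. The core of compound 2 and the core of compound 3 differ in more than one place, and that difference is not broken down here.

Compound 3 and compound 1 differ by one change only: chloro in place of bromo on an aromatic carbon. With both values being limits, the step that the two limits leave unreadable from compound 3 to compound 1 cannot be sized.

Compound 4 `C=C1C(=O)[C@]23C[C@@]1(O)CC[C@H]2c1ccc(OS(=O)(=O)c2ccc(C)cc2)c(C)c1[C@@H]3Cn1cc(-c2ccc(Cl)cc2)nn1` has not been measured. It is made from compound 2 by the same change: chloro in place of bromo on an aromatic carbon. The place of the change is described in the same words in both pairs, so it is the same change.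

Among the measured compounds shown here, the step from compound 2 to compound 4 in this assay is expected to be small, a 1.4-fold higher number from compound 2 to compound 4 (0.15 log units; within the scatter), since the only measured instance of this change gives no readable size and the halogens exchanged are close in kind. The expectation rests on compound 2 at 250 nM as the starting point. Compound 4 is therefore estimated at 350 nM, with a range from 120 nM to 1200 nM.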

Compound 4, half-maximal inhibitory concentration: 1440 nM
Estimate against measurement, compound 4: 4.1-fold (0.61 log units) below; the measured number lies above the stated range.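

In this assay, among the compounds shown here, chloro in place of bromo on the core of compound 2 gives a 5.8-fold higher number from compound 2 to compound 4 (0.76 log units; beyond the scatter), so on this core the exchange of 4-bromophenyl for 4-chlorophenyl carries a step beyond the scatter, even though only one heavy atom changes and the counts of donors, acceptors and rings stay the same. The matching step from compound 3 to compound 1 cannot be read, because both compounds sit at a limit: the limit of > 20000 nM in this assay, at which 2 of the 4 values shown sit.

The series therefore holds a single sized instance of this change, which shows what it does on the core of compound 2 but neither supports nor contradicts the same step on the core of compound 3, so nothing here establishes that the step carries from one core to another.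

Still open, going by these compounds, is whether the step follows a trend across the aromatic ring's substituent, since only bromo and chloro appear at this place and a fluoro, methoxy or carboxylic acid group on the core of compound 2 would be needed to show one. Also open, on these data alone, is whether a step of this size would appear on any further core.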